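Swapping a pyrazole for an imidazole in compound 2

The source may report more compounds than this note shows. Statements on the series, on what has been measured and on what is new or still open speak of the compounds shown alone.

For the measured compounds named here, in a physicochemical assay for lipophilicity (a higher number here means a more lipophilic compound, a lower number a more polar compound), only two compounds have numbers so far. Compound 1 (`CN(C)Cc1nccn1-c1ccc(N2CCC(NS(=O)(=O)CCc3ccc(Cl)s3)C2=O)c(F)c1`) gives 2.32 and compound 2 (`CN(C)Cc1ccnn1-c1ccc(N2CCC(NS(=O)(=O)c3cc4ccc(Cl)cc4s3)C2=O)c(F)c1`) gives 3.35 as the higher of the pair, a gap beyond the scatter. The two differ in more than one place, so that gap does not size any single change. Compound 3 (`CN(C)Cc1cn(-c2ccc(N3CCC(NS(=O)(=O)c4cc5ccc(Cl)cc5s4)C3=O)c(F)c2)cn1`) has the same atoms as compound 2, joined differently: 4-((dimethylamino)methyl)-1H-imidazol-1-yl in place of 5-((dimethylamino)methyl)-1H-pyrazol-1-yl on an aromatic carbon. Going by the values given here, no measured pair isolates this swap, so the expectation is a judgement with wide margins. In this assay a moderate fall is expected (a number 0.45 log units lower from compound 2 to compound 3 (beyond the scatter)), which would lie only just beyond the scatter. For compound 3 the estimated value is 2.9 with an expected range from 2.4 to 3.35 once it is measured.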

Compound 3, distribution coefficient: 1.82
Estimate against measurement, compound 3: 1.08 log units above; the measured number lies below the stated range.
By their numbers in this assay, from the lowest: compound 3; then compound 1; then compound 2.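

In this assay, for the compounds shown here, putting 4-((dimethylamino)methyl)-1H-imidazol-1-yl in place of 5-((dimethylamino)methyl)-1H-pyrazol-1-yl gives a number 1.53 log units lower from compound 2 to compound 3 (beyond the scatter), the first step here that sizes a single change at this position. The two groups match in heavy atoms, hetero atoms, donors and acceptors, so these counts do not separate them, yet the large step shows that how the same atoms are joined at this place matters on its own. No measurement shown accounts for the size of the step.

As far as these compounds go, it remains open whether a step of this size would persist with a pyrrolidine in place of the dimethylamino group. From the compounds shown here alone, it is also open whether the same exchange would give a similar step with the sulfonamide part of compound 1.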